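A few compounds are considered here, and "the series" means these few. Any claim that something is new, unique, unknown or untested is made for them only; others in the source may bear on it.

Compound 3 `Cc1cnn(C(=O)N2CCCN(Cc3ccc(OCc4ccccc4)cc3)CC2)c1` gives the highest number of the three measured in an assay on membranes from brain for binding affinity to Monoglyceride lipase (Mus musculus), read by fluorescence, with stated times of 1 h and 30 min (on this read-out lower numbers stand for stronger inhibition and higher numbers for weaker inhibition), at 9500 nM. Compound 1 `Cc1cnn(C(=O)NCc2ccc(OCc3ccccc3)cc2)c1` gives 1000 nM in this assay, and compound 2 `O=C(NCc1ccc(OCc2ccccc2)cc1)n1cccn1` gives 900 nM. Compound 4 `O=C(N1CCCN(Cc2ccc(OCc3ccccc3)cc2)CC1)n1cccn1` differs from compound 3 by hydrogen in place of methyl on an aromatic carbon; the same difference cut one bond further out reads 4-methyl-1H-pyrazol-1-yl to 1H-pyrazol-1-yl. Among the measured compounds shown here, the only measured step of this kind, a 1.1-fold lower number from compound 1 to compound 2 (0.05 log units; within the scatter), lies within the scatter, so no change beyond the scatter is expected here either. The expected step is therefore a 1.1-fold lower number from compound 3 to compound 4 (0.02 log units; within the scatter). For compound 4 the estimated value in this assay is 9000 nM, lying between 4000 nM and 20000 nM.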

Compound 4, half-maximal inhibitory concentration: 10000 nM
The estimate for compound 4 lay 1.1-fold (0.05 log units) below the measured number; measured number inside the range.
By their numbers in this assay, from the lowest: compounds 2 and 1 (each within the scatter of the next); then compounds 3 and 4 (each within the scatter of the next).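

On a second core in this assay, exchanging the methyl on this aromatic carbon for hydrogen again produces no change beyond the scatter, with a 1.1-fold higher number from compound 3 to compound 4 (0.02 log units; within the scatter). The earlier compounds showed this for one pair only, whereas the exchange now reads the same on both cores: the same change on two cores in this assay, a 1.1-fold lower number (0.05 log units; within the scatter) from compound 1 to compound 2 and a 1.1-fold higher number (0.02 log units; within the scatter) from compound 3 to compound 4, 1.2-fold (0.07 log units) apart, within the scatter of two such steps

The compounds shown carry only methyl or hydrogen on this carbon. From the compounds shown here alone, whether an ethyl group, a chlorine atom or a methoxy group there would shift the number in this assay on either core remains open.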